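A Pyridyl Replacement on a Fused Six-Ring Core

This account rests on a few compounds, and the source may have more. Where it says the series, first, only, none or still open, it means among the compounds named here.

Compound 3 `COc1ccc(-c2c3ccc4ccccc4c3nc3c2c(C)nc2c4ccccc4ccc32)cc1` gives the highest of the two numbers shown in a functional assay on AGS cells (Homo sapiens) for cytotoxicity, read by MTT assay, with a stated time of 48 h (on this read-out higher numbers stand for weaker inhibition and lower numbers for stronger inhibition), namely 66400 nM. Its nearest neighbour, compound 1 `Cc1nc2c3ccccc3ccc2c2nc3c(ccc4ccccc43)c(-c3cc([N+](=O)[O-])ccc3N)c12`, gives 17800 nM. Compound 2 `Cc1nc2c3ccccc3ccc2c2nc3c(ccc4ccccc43)c(C)c12` gives only a limit, > 80000 nM, in this assay. The step of a 3.7-fold higher number from compound 1 to compound 3 (0.57 log units; beyond the scatter) was modest, whereas an at least 1.2-fold lower number from compound 2 to compound 3 (0.08 log units; that floor lies within the scatter) stays within the scatter. Compound 4 `Cc1nc2c3ccccc3ccc2c2nc3c(ccc4ccccc43)c(-c3cccnc3)c12` differs from compound 3 by pyridin-3-yl in place of 4-methoxyphenyl on an aromatic carbon. Only these two measured steps bear on the change, and neither involves a pyridin-3-yl; the closest comparison, one aryl group replacing another, is a 3.7-fold higher number from compound 1 to compound 3 (0.57 log units; beyond the scatter). No step beyond the scatter is therefore expected for a 1.1-fold lower number from compound 3 to compound 4 (0.04 log units; within the scatter), though a limit remains possible. Compound 4 is estimated at 60000 nM, within 25000 nM to 150000 nM.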

Compound 4, half-maximal inhibitory concentration: 3960 nM
Compound 4: middle estimate off by 15-fold (1.18 log units), on the high side; measured number below the stated range.
By their numbers in this assay, from the lowest: compound 4; then compound 1; then compound 3. At a limit, above all of these: compound 2.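

Replacing 4-methoxyphenyl with pyridin-3-yl gives a 17-fold lower number from compound 3 to compound 4 (1.22 log units; beyond the scatter), so at this position the kind of aromatic ring, not merely the presence of one, shifts the number. The same group also improves on the 2-amino-5-nitrophenyl group, which had given the lowest earlier number, with a 4.5-fold lower number from compound 1 to compound 4 (0.65 log units; beyond the scatter). Against methyl the step is an at least 20-fold lower number from compound 2 to compound 4 (1.30 log units; beyond the scatter), which is only a floor, as compound 2 stands at a limit: the limit of > 80000 nM in this assay, at which 1 of the 4 values shown sits.

Open, on these data alone, is whether phenyl, pyridin-2-yl or pyridin-4-yl at this position would give a number like that of compound 4, and so whether the ring nitrogen or its placing counts.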